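Replacing the azole at the branch carbon of compound 3

This account rests on a few compounds, and the source may have more. Where it says the series, first, only, none or still open, it means among the compounds named here.

Among the measured compounds shown here, compound 3 `CC(C)C(c1noc(=O)[nH]1)c1ccc(-c2ccc3cccc(F)c3c2)[nH]c1=O` gives 41 nM in a functional assay on CHO cells for antagonist activity at prostaglandin E2 receptor EP3 subtype (Homo sapiens), read by cAMP accumulation (on this read-out lower numbers stand for stronger inhibition and higher numbers for weaker inhibition), the highest of the three numbers measured so far. Compound 1 `CC(C)C(c1nnc[nH]1)c1ccc(-c2ccc3cccc(F)c3c2)[nH]c1=O` gives 21 nM and compound 2 `CC(C)NC(=O)CC(c1ccc(-c2ccc3cccc(F)c3c2)[nH]c1=O)C(C)C` gives 15 nM. Both differ from compound 3 only at the same saturated chain carbon: a 2.0-fold higher number from compound 1 to compound 3 (0.29 log units; within the scatter); a 2.7-fold higher number from compound 2 to compound 3 (0.44 log units; beyond the scatter). Compound 4 `CC(C)C(/C=C1/CCNC1=O)c1ccc(-c2ccc3cccc(F)c3c2)[nH]c1=O` carries a group of 7 heavy atoms (5 carbon, 1 nitrogen, 1 oxygen; one five-membered non-aromatic ring with 1 hetero atom) in place of a group of 6 heavy atoms (2 carbon, 2 nitrogen, 2 oxygen; one five-membered aromatic ring with 3 hetero atoms), on a saturated chain carbon bound to an aromatic carbon and a saturated chain carbon. The entering group is closer in make-up to the open group of compound 2 than to either azole, and given a 2.7-fold higher number from compound 2 to compound 3 (0.44 log units; beyond the scatter) a move back toward lower numbers, modest in size, is expected: a 2.1-fold lower number from compound 3 to compound 4 (0.31 log units; beyond the scatter). Compound 4 is accordingly estimated at 20 nM, with a range of 8 nM to 50 nM.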

Compound 4, half-maximal inhibitory concentration: 8.1 nM
Estimate against measurement, compound 4: 2.5-fold (0.39 log units) above, and the stated range covers the measured number.
By their numbers in this assay, from the lowest: compounds 4, 2, 1 and 3 (each within the scatter of the next, the first and the last beyond it).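

At this saturated chain carbon in this assay, the five-membered non-aromatic ring with 1 hetero atom outperforms both azoles (a 5.1-fold lower number from compound 3 to compound 4 (0.70 log units; beyond the scatter); a 2.6-fold lower number from compound 1 to compound 4 (0.41 log units; beyond the scatter)), so an aromatic ring at this carbon is not required for activity. The ring cannot be separated from the open group of compound 2 (a 1.9-fold lower number from compound 2 to compound 4 (0.27 log units; within the scatter)). No measurement here explains these differences.

Still open, going by these compounds, is whether the double bond linking the ring to the chain is needed. Also open, on these data alone, is how a carboxylic acid or an amine would behave at this carbon.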